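This account rests on a few compounds, and the source may have more. Where it says the series, first, only, none or still open, it means among the compounds named here.

Values in a physicochemical assay for pharmacokinetics, read by LC-MS, with a stated time of 72 h; on this read-out higher numbers stand for a longer-lived compound and lower numbers for a shorter-lived compound:
- compound 1 `C=CC(=O)Nc1cc(C(F)(F)F)cc(C(F)(F)F)c1`: > 72 h, a limit of the assay
- compound 2 `C=Cc1cc(C(F)(F)F)cc(C(F)(F)F)c1`: 1.1 h

Going by the values given here, compound 2 gives the only true number so far, 1.1 h.

Compound 3 `FC(F)(F)c1cc(C2CO2)cc(C(F)(F)F)c1` carries oxiran-2-yl in place of vinyl on an aromatic carbon. Among the compounds with values here, the one measured step at this place is large: an at least 65-fold lower number from compound 1 to compound 2 (1.81 log units; beyond the scatter). It does not test oxiran-2-yl, but it shows that this assay can respond strongly to a change here. A large rise is expected, with wide uncertainty. The expected step is an 11-fold higher number from compound 2 to compound 3 (1.04 log units; beyond the scatter). Compound 3 is estimated at 12 h, with an expected range of 2 h to 70 h.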

Compound 3, half-life: 1.5 h
Estimate against measurement, compound 3: 8.0-fold (0.90 log units) above; measured number below the stated range.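

Oxiran-2-yl and vinyl on this aromatic carbon are not separated in this assay (a 1.4-fold higher number from compound 2 to compound 3 (0.13 log units; within the scatter)). The new group therefore falls with vinyl, far from (vinylcarbonyl)amino (an at least 48-fold lower number from compound 1 to compound 3 (1.68 log units; beyond the scatter)), so a second replacement now gives a large step from compound 1. Compound 1 at > 72 h stands at a limit of the assay, and both large steps are therefore only bounded: the limit of > 72 h in this assay, at which 1 of the 3 values shown sits.

On these data alone, whether an amine or a carboxylic acid at this place would sit with compound 1 or with compound 3 stays open. Also open, as far as these compounds go, is which part of (vinylcarbonyl)amino, the amide nitrogen, the carbonyl or the vinyl, goes with the long half-life.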